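A few compounds are considered here, and "the series" means these few. Any claim that something is new, unique, unknown or untested is made for them only; others in the source may bear on it.

Measured so far: compound 1 `CN(C)CCN(CCN(C)C)c1cccc(C(=O)N2CCc3ccc(OS(N)(=O)=O)cc3C2)c1` with 0% in an assay on HEK293 cells for inhibition of Steryl-sulfatase (Homo sapiens), tested at 0.1 uM (a lower number here means a weaker effect, a higher number a stronger effect of the compound at the concentration tested), and compound 2 `CCN(Cc1cccc(Br)c1)c1ccc(C(=O)N2CCc3ccc(OS(N)(=O)=O)cc3C2)cc1` with 80.2%.

Compound 1 stands lowest of the two numbers, and compound 2 lies above it beyond the scatter. Compound 3 `CN(CCN1CCCCC1)c1cccc(C(=O)N2CCc3ccc(OS(N)(=O)=O)cc3C2)c1` is not yet measured and differs from compound 1 in one place: methyl(2-(piperidin-1-yl)ethyl)amino in place of bis(2-(dimethylamino)ethyl)amino on an aromatic carbon. For the measured compounds named here, no step between measured compounds that differ in one place is available, so the change is judged from the structures alone. Only a modest rise in this assay is expected, the step from a number 20 percentage points higher from compound 1 to compound 3 (beyond the scatter) being the estimate. Compound 3 is expected to give 20%, with a range from 0% to 55%.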

Compound 3, a percentage reported as inhibition, at one concentration (the size of the read-out at that concentration, not a potency): 24.5%
For compound 3 the middle estimate is 4.5 percentage points below the measured one; measured number inside the range.
By their numbers in this assay, from the lowest: compound 1; then compound 3; then compound 2.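

In this assay, methyl(2-(piperidin-1-yl)ethyl)amino in place of bis(2-(dimethylamino)ethyl)amino on an aromatic carbon gives a number 24.5 percentage points higher from compound 1 to compound 3 (beyond the scatter) and shows that this position responds to a change of its amine side chain. The swap adds a six-membered non-aromatic ring and removes a nitrogen at once, so this single step cannot separate the two changes. No available evidence bears on the reason for the step. As far as these compounds go, it remains open whether the ring or the lost dimethylamino arm matters more, and how a morpholine would read at this place.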